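The source may report more compounds than this note shows. Statements on the series, on what has been measured and on what is new or still open speak of the compounds shown alone.

Compound 1 `c1ccc(-c2cn3ccnc3c(-c3ccc4ncn(C5CCCCC5)c4c3)n2)cc1`: 63.9% in a functional assay on OVCAR-8 cells (Homo sapiens) for inhibition, read by sulforhodamine B assay, with a stated time of 48 h, tested at 10 uM; a higher number here means more inhibition at the concentration tested (going by the name of the read-out), a lower number less inhibition
Compound 2 `CC(=O)c1ccc(-c2cn3ccnc3c(-c3ccc4ncn(C5CCCCC5)c4c3)n2)cc1`: 6.38% in this assay

For the measured compounds named here, compound 2 stands lowest of the two numbers measured; the only step, a number 57.5 percentage points lower from compound 1 to compound 2 (beyond the scatter), was large. Compound 3 `Clc1ccc(-c2cn3ccnc3c(-c3ccc4ncn(C5CCCCC5)c4c3)n2)cc1` differs from compound 2 by chloro in place of acetyl on an aromatic carbon. Going by the values given here, no measured step shows chloro directly, but compound 2 holds the acetyl whose arrival brought the large fall, so its removal is expected to restore much of the inhibition. The estimated step is a number 38.6 percentage points higher from compound 2 to compound 3 (beyond the scatter). Compound 3 is therefore estimated at 45%, with a range from 10% to 75%.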

Compound 3, a percentage reported as inhibition, at one concentration (the size of the read-out at that concentration, not a potency): 3.78%
Estimate against measurement, compound 3: 41.2 percentage points above; measured number below the stated range.
By their numbers in this assay, from the lowest: compounds 3 and 2 (each within the scatter of the next); then compound 1.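

In this assay, chloro in place of hydrogen on this aromatic carbon, para to a large group, also cost inhibition, with a number 60.1 percentage points lower from compound 1 to compound 3 (beyond the scatter), so the large fall is not confined to acetyl. Exchanging acetyl for chloro gave a number 2.6 percentage points lower from compound 2 to compound 3 (within the scatter), and these two groups, of 3 heavy atoms and 1 heavy atom, could not be told apart here. No evidence is available that accounts for the fall. The compounds shown leave open whether fluoro, methoxy or an amine at this place would retain the inhibition of compound 1.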